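The source may hold more compounds than are shown below. What is called first, only, known or untested is meant among the compounds shown, and "the series" means these compounds.

Compound 1 `COc1cccc(Nc2nc3c(c(Oc4cccc(NC(=O)C=C(C)C)c4)n2)CSCC3)c1`, compound 2 `COc1cccc(Nc2nc3c(c(Oc4cccc(NC(=O)/C=C/C(C)C)c4)n2)CSCC3)c1` and compound 3 `COc1ccc(Nc2nc3c(c(Oc4cccc(NC(=O)C=C(C)C)c4)n2)CSCC3)cc1` were measured; compound 4 `COc1ccc(Nc2nc3c(c(Oc4cccc(NC(=O)/C=C/C(C)C)c4)n2)CSCC3)cc1` was not.

In a functional assay on MCF7 cells (Homo sapiens) for antiproliferative activity, read by MTT assay, with a stated time of 72 h (a lower number here means a stronger inhibitor, a higher number a weaker inhibitor), compound 1 gives only a limit, > 50000 nM. Compound 2 gives 21800 nM in this assay, so the change 3-methylbut-1-en-1-yl in place of 2-methylprop-1-en-1-yl on a carbonyl carbon produced an at least 2.2-fold lower number from compound 1 to compound 2 (0.36 log units; beyond the scatter). Compound 3 also gives only a limit in this assay, > 50000 nM. The cores of compound 1 and compound 3 differ by 4-methoxyphenyl in place of 3-methoxyphenyl on a nitrogen on an aromatic ring, and that step is a step that the two limits leave unreadable from compound 1 to compound 3; the limit of > 50000 nM in this assay, at which 2 of the 3 values shown sit, is why.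

Compound 4 carries the same change as compound 2, namely (3-methylbut-1-en-1-yl in place of 2-methylprop-1-en-1-yl on a carbonyl carbon), at the same place. Because the step of an at least 2.2-fold lower number from compound 1 to compound 2 (0.36 log units; beyond the scatter) was at least modest, a step of similar size is expected, and compound 4 is estimated to reach about an at least 2.0-fold lower number from compound 3 to compound 4 (0.30 log units; that floor lies within the scatter). Compound 4 is therefore expected to show roughly 25000 nM in this assay, between 10000 nM and 50000 nM.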

Compound 4, half-maximal inhibitory concentration: > 50000 nM
Compound 4: only a limit was reported (the forecaster's own chance of this, stated with the estimate: 40%); middle value at least 2.0-fold (0.30 log units) from the limit.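

In this assay compound 4 gives > 50000 nM, which is a limit and not a number. The change to 3-methylbut-1-en-1-yl on the carbonyl carbon therefore cannot be shown either to carry over to the core of compound 3 or to fail there, and the steps between limits cannot be read, because of this: the limit of > 50000 nM in this assay, at which 3 of the 4 values shown sit. The one readable new step is an at least 2.2-fold higher number from compound 2 to compound 4 (0.36 log units; beyond the scatter), for 4-methoxyphenyl in place of 3-methoxyphenyl on a nitrogen on an aromatic ring, and it describes this pair only.

The compounds shown leave open how the change behaves on a core whose starting compound gives a measured number. They also leave open how a longer chain, or a chain ending in an amine or a carboxylic acid, would read on the carbonyl carbon in this assay.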